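The source may hold more compounds than are shown below. What is called first, only, known or untested is meant among the compounds shown, and "the series" means these compounds.

Working notes on the series. The shared core carries a cycloalkyl or oxolanyl amine and an aryl group, and all three measured compounds were tested in an assay on CHO cells for displacement of a labelled ligand from adenosine receptor A1 (Homo sapiens), read by scintillation counting, with a stated time of 3 h; on this read-out lower numbers stand for stronger inhibition and higher numbers for weaker inhibition. Compound 1 `CCn1c(-c2ccccc2)nc2c(NC3CCCCC3)ncnc21` gives 10 nM. Compound 3 `CCn1c(-c2ccccc2)nc2c(NC3CCOC3)ncnc21` gives 10 nM, so that the step of no change at the digits printed from compound 1 to compound 3 (within the scatter) shows the oxolan-3-yl amine is carried without loss. Compound 2 `Cn1c(-c2cccc(Cl)c2)nc2c(NC3CCCC3)ncnc21`, which pairs a methyl on the ring nitrogen with a cyclopentyl amine and a 3-chlorophenyl group, gives 6.5 nM; its gaps to compound 1 and to compound 3 are within the scatter, so the three sit together at the low end of the scale.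

Compound 4 `Cc1ccc(-c2nc3c(NC4CCCC4)ncnc3n2C)cc1` is the next compound to be measured in this assay. It differs from compound 2 in one place: 4-methylphenyl in place of 3-chlorophenyl on an aromatic carbon. Going by the values given here, no measured step in this set touches the aryl group; the only measured step, from compound 1 to compound 3, concerns the amine and is flat. Among the compounds with values here, the aryl change therefore has no direct precedent here, and a modest step in either direction is conceivable. Given the close grouping of compound 1, compound 2 and compound 3, the expected step of a 1.8-fold higher number from compound 2 to compound 4 (0.27 log units; within the scatter) is small. Compound 4 is estimated at 12 nM, with a range from 4 nM to 35 nM.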

Compound 4, inhibition constant: 8 nM
For compound 4 the middle estimate is 1.5-fold (0.18 log units) above the measured one; measured number inside the range.
By their numbers in this assay, from the lowest: compounds 2, 4, 1 and 3 (each within the scatter of the next).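

In this assay, going by these compounds alone, the step of a 1.2-fold higher number from compound 2 to compound 4 (0.09 log units; within the scatter) is the first measured change at the aryl group, on the aromatic carbon of the five-membered aromatic ring with 2 nitrogen, whereas the earlier step of no change at the digits printed from compound 1 to compound 3 (within the scatter) concerned only the amine. With the methyl group and the cyclopentyl amine held fixed, 4-methylphenyl stands in for 3-chlorophenyl with a step within the scatter, so this exchange of aryl groups, like the amine exchange, leaves the number flat. No supporting evidence bears on why this position tolerates the exchange.

Because the step changes both the substituent and its place on the phenyl ring, it cannot show whether either change alone would also be flat; 3-methylphenyl or 4-chlorophenyl on the same core would separate the two. Whether the flat response extends to a phenyl ring carrying a carboxylic acid, an amine or a longer chain also remains open, as the compounds shown have only a methyl group or a chlorine on this ring, or no substituent at all.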